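Bridged bicycle to cycloheptyl on the amide nitrogen

The compounds below may be only part of what the source reports. "The series", "measured", "known", "first", "only" and "open" are said of these compounds alone.

Measured in an ADME assay on MRC5 cells (Homo sapiens) for inhibition, with a stated time of 72 h; on this read-out lower numbers stand for an effect already at smaller amounts and higher numbers for an effect only at larger amounts of compound:
Compound 1 `CCc1ccccc1C(=O)Nc1c[nH]nc1C(=O)N[C@H]1CC[C@H](OC)CC1` gives 3400 nM
Compound 2 `COc1cccc(OC)c1C(=O)Nc1c[nH]nc1C(=O)NC1CC2CCC1C2` gives > 50000 nM
Compound 3 `CO[C@H]1CC[C@H](NC(=O)c2n[nH]cc2NC(=O)c2ccccc2)CC1` gives 800 nM

Compound 2 stands at the limit of > 50000 nM in this assay, at which 1 of the 3 values shown sits; this is a limit of the assay and not a number. Compound 4 `COc1cccc(OC)c1C(=O)Nc1c[nH]nc1C(=O)NC1CCCCCC1` differs from compound 2 by a group of 7 heavy atoms (7 carbon; one seven-membered non-aromatic ring of carbon only) in place of a group of 7 heavy atoms (7 carbon; 2 five-membered non-aromatic rings of carbon only), on an amide-type nitrogen. Going by the values given here, the only measured step, a 4.3-fold lower number from compound 1 to compound 3 (0.63 log units; beyond the scatter), concerns a group on an aromatic carbon and not the group on the amide nitrogen, so no measured step bears directly on this change. With compound 2 at the limit, compound 4 is expected to remain weak, estimated at 60000 nM with a range from 15000 nM to 300000 nM, which means an expected step that the limit leaves unreadable from compound 2 to compound 4, and a result reported only as a limit is likely.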

Compound 4, half-maximal effective concentration: 42000 nM
Compound 4: middle estimate off by 1.4-fold (0.15 log units), on the high side; low and high end bracket the measured number.
By their numbers in this assay, from the lowest: compound 3; then compound 1; then compound 4. At a limit, above all of these: compound 2.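

Compound 2 gives no number on this read-out, only a limit of the assay: the limit of > 50000 nM in this assay, at which 1 of the 4 values shown sits. With cycloheptyl on the amide nitrogen, compound 4 gives a real number in this assay, 42000 nM, so this position can carry a group that stays within the measurable range. The step is an at least 1.1-fold lower number from compound 2 to compound 4 (0.07 log units; that floor lies within the scatter), which means the change may be small or larger, and its true size cannot be read.

From the compounds shown here alone, what a smaller ring such as cyclopentyl, or a ring carrying an amine, would do at this amide nitrogen remains open.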